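Benzyloxy Replacing Hydroxy(phenyl)methyl on the Shared Core

A few compounds are considered here, and "the series" means these few. Any claim that something is new, unique, unknown or untested is made for them only; others in the source may bear on it.

Measured compounds:
compound 1, `CCS(=O)(=O)N(Cc1cccnc1)c1cccc(C(O)c2ccccc2)c1`, 2500 nM
compound 2, `C=C(c1ccccc1)c1cccc(N(Cc2cccnc2)S(=O)(=O)CC)c1`, 200 nM
compound 3, `CCS(=O)(=O)N(Cc1cccnc1)c1cccc(COc2ccccc2)c1`, 160 nM

In an assay on isolated protein with metabotropic glutamate receptor 2 (Homo sapiens) as the target (a higher number here means that more compound is needed for the effect, a lower number that less compound is needed), compound 1 gives the highest of the three numbers. Its nearest neighbour is compound 2, reached by a 13-fold lower number from compound 1 to compound 2 (1.10 log units; beyond the scatter), and the furthest is compound 3, reached by a 16-fold lower number from compound 1 to compound 3 (1.19 log units; beyond the scatter). Between those two the difference is small: a 1.3-fold lower number from compound 2 to compound 3 (0.10 log units; within the scatter).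

Compound 4, `CCS(=O)(=O)N(Cc1cccnc1)c1cccc(OCc2ccccc2)c1`, has not yet been measured in this assay. It differs from compound 1 in one place: benzyloxy in place of hydroxy(phenyl)methyl on an aromatic carbon. The group that leaves and the group that enters are built from the same atoms, and compound 4 is likewise an isomer of compound 3 in this respect.

Both measured steps away from compound 1 bear on this change, since each also replaces hydroxy(phenyl)methyl on that aromatic carbon, and both were large in the same direction. The expected step in this assay is therefore a large fall in the number, a 13-fold lower number from compound 1 to compound 4 (1.10 log units; beyond the scatter), in line with what compound 3 shows at 160 nM. Compound 4 is thus estimated at 200 nM, with a range from 60 nM to 700 nM.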

Compound 4, half-maximal effective concentration: 440 nM
Compound 4: the middle estimate sits 2.2-fold (0.34 log units) below what was measured, and the stated range covers the measured number.
By their numbers in this assay, from the lowest: compounds 3 and 2 (each within the scatter of the next); then compound 4; then compound 1.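

In this assay, benzyloxy also lowers the number on this aromatic carbon, a 5.7-fold lower number from compound 1 to compound 4 (0.75 log units; beyond the scatter), and here the hydrogen-bond donor of hydroxy(phenyl)methyl is gone while the atoms stay the same, though the step is smaller than those to the other two groups. The replacements are not interchangeable: there is a 2.8-fold higher number from compound 3 to compound 4 (0.44 log units; beyond the scatter), and likewise a 2.2-fold higher number from compound 2 to compound 4 (0.34 log units; beyond the scatter), both beyond the scatter, whereas compound 2 and compound 3 lie within the scatter of each other, so joining the same atoms in a different order, as benzyloxy rather than phenoxymethyl, changes the number measurably. Nothing available explains these differences.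

The compounds shown leave open how much of the fall from compound 1 belongs to the loss of the hydroxy group alone, a question that benzyl on the same carbon would address, as every replacement here also alters the link to the phenyl ring. They also leave open whether a longer chain in that link, or an amine in place of its oxygen, would give a number nearer that of compound 3 or that of compound 4.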